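A few compounds are considered here, and "the series" means these few. Any claim that something is new, unique, unknown or untested is made for them only; others in the source may bear on it.

Compound 1 `O=C(CI)NCCCNc1ncnc2c1ncn2[C@@H]1O[C@H](COP(=O)(O)OP(=O)(O)OP(=O)(O)O)[C@@H](O)[C@H]1O`: 0%
Compound 2 `O=C(CI)NCCC(=O)NCCCCCCNc1ncnc2c1ncn2[C@@H]1O[C@H](COP(=O)(O)OP(=O)(O)OP(=O)(O)O)[C@@H](O)[C@H]1O`: 0%
Compound 3 `O=C(CI)NCCNc1ncnc2c1ncn2[C@@H]1O[C@H](COP(=O)(O)OP(=O)(O)OP(=O)(O)O)[C@@H](O)[C@H]1O`: 0%

In an assay on isolated protein for inhibition of hexokinase-2 (Rattus norvegicus), with a stated time of 6 h, tested at 10 mM (a higher number here means more inhibition at the concentration tested (going by the name of the read-out), a lower number less inhibition), compound 3 gives 0%, level with compound 1 and compound 2 within the scatter; its nearest neighbour is compound 1, its furthest compound 2, and neither gap goes beyond the scatter. Compound 4 `O=C(I)NCC(=O)NCCCCCCNc1ncnc2c1ncn2[C@@H]1O[C@H](COP(=O)(O)OP(=O)(O)OP(=O)(O)O)[C@@H](O)[C@H]1O` has yet to be measured. It differs from compound 3 by a group of 12 heavy atoms (7 carbon, 2 nitrogen, 2 oxygen, 1 iodine; no ring) in place of a group of 5 heavy atoms (2 carbon, 1 nitrogen, 1 oxygen, 1 iodine; no ring), on a saturated chain carbon, two bonds along the chain from a nitrogen on an aromatic ring. For the measured compounds named here, the one measured step that touches this part of the linker, no change at the digits printed from compound 1 to compound 3 (within the scatter), was flat, and compound 2, carrying a different linker, sits at the same value. Nothing among the three measured compounds points to movement, so the step of no change at the digits printed from compound 3 to compound 4 (within the scatter) is expected to stay within the scatter. For compound 4 in this assay the estimate is 0%, between -10% and 10%.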

Compound 4, a percentage reported as inhibition, at one concentration (the size of the read-out at that concentration, not a potency): 0%
For compound 4 middle estimate and measured number coincide at the digits printed; the measured number falls inside the stated range.
By their numbers in this assay, from the lowest: compounds 1, 2, 3 and 4 (each within the scatter of the next).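

In this assay, putting the larger group on the saturated chain carbon, two bonds along the chain from a nitrogen on an aromatic ring, gives no change at the digits printed from compound 3 to compound 4 (within the scatter), and the comparisons with the other two compounds give no change at the digits printed from compound 2 to compound 4 (within the scatter) and no change at the digits printed from compound 1 to compound 4 (within the scatter). The flat picture therefore now extends to a compound that lacks the ((iodomethyl)carbonyl)amino end shared by the other three. No available evidence accounts for this flat result. With all four compounds level, the compounds shown do not reveal whether anything at this position can produce inhibition. As far as these compounds go, whether an amine or a carboxylic acid at the chain end would move the read-out remains open.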